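Piperidine replaces the diamine on a decylphenyl oxadiazole

The source may hold more compounds than are shown below. What is called first, only, known or untested is meant among the compounds shown, and "the series" means these compounds.

Measured so far in an assay on HeLa cells for inhibition of sphingosine-1-phosphate transporter SPNS2 (Mus musculus), read by LC-MS, tested at 2 uM; on this read-out lower numbers stand for less inhibition and higher numbers for more inhibition at the one concentration tested (going by the name of the read-out):
- compound 1 `CCCCCCCCCCc1ccc(-c2noc(CCCN(C)C)n2)cc1`: 8%
- compound 2 `CCCCCCCCCCc1ccc(-c2noc(CN3CCNCC3)n2)cc1`: 19%
- compound 3 `CCCCCCCCCCc1ccc(-c2noc([C@@H](N)CCN)n2)cc1`: 14%

Compound 3 holds the second highest of the three numbers, though neither gap leaves the scatter: a number 5 percentage points lower from compound 2 to compound 3 (within the scatter) and a number 6 percentage points higher from compound 1 to compound 3 (within the scatter). Compound 4 `CCCCCCCCCCc1ccc(-c2noc(CCCN3CCCCC3)n2)cc1` differs from compound 3 by 3-(piperidin-1-yl)propyl in place of 1,3-diaminopropyl on an aromatic carbon. Among the measured compounds shown here, the step that bears on it is the one between compound 1 and compound 3, where a number 6 percentage points higher from compound 1 to compound 3 (within the scatter), since the group entering in compound 4 resembles the 3-(dimethylamino)propyl of compound 1. The other step, a number 11 percentage points higher from compound 1 to compound 2 (beyond the scatter), is modest. Compound 4 is therefore expected to move only a number 3 percentage points lower from compound 3 to compound 4 (within the scatter), no more than the scatter, and its estimated value in this assay is 11%, in the range 0% to 24%.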

Compound 4, a percentage reported as inhibition, at one concentration (the size of the read-out at that concentration, not a potency): 0%
Compound 4: the middle estimate sits 11 percentage points above what was measured; low and high end bracket the measured number.
By their numbers in this assay, from the lowest: compounds 4, 1, 3 and 2 (each within the scatter of the next, the first and the last beyond it).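

With 3-(piperidin-1-yl)propyl in place of 1,3-diaminopropyl on this aromatic carbon, the number falls in this assay (a number 14 percentage points lower from compound 3 to compound 4 (beyond the scatter)), and it also falls beyond the scatter against the piperazin-1-yl compound (a number 19 percentage points lower from compound 2 to compound 4 (beyond the scatter)). Piperidin-1-yl in place of dimethylamino on the same chain, however, gives no readable change (a number 8 percentage points lower from compound 1 to compound 4 (within the scatter)). At this position, then, the piperidine chain cannot be told apart from the dimethylamino chain, but it can be from the other two groups.

Going by these compounds, whether a morpholin-4-yl group or a carboxylic acid on this chain would read differently stays open. Nothing shown here accounts for these steps.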